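Nitro for Fluoro on the Pendant Phenyl Ring

This account rests on a few compounds, and the source may have more. Where it says the series, first, only, none or still open, it means among the compounds named here.

Compound 2 `Cn1cc(-c2cnc3[nH]cc(-c4cccc(F)c4)c3c2)cn1` gives 3000 nM in a physicochemical assay for solubility, read by LC-MS, in phosphate buffer, measured as thermodynamic solubility, with a stated time of 24 h, at pH 7.4 (on this read-out higher numbers stand for higher solubility and lower numbers for lower solubility), the lowest of the three numbers in hand. Compound 1 `Cn1cc(-c2cnc3[nH]cc(-c4ccccc4)c3c2)cn1` gives 20000 nM, and compound 3 `Cn1cc(-c2cnc3[nH]cc(-c4ccccc4F)c3c2)cn1` gives 14000 nM. The steps among them are a 6.7-fold lower number from compound 1 to compound 2 (0.82 log units; beyond the scatter), a 1.4-fold lower number from compound 1 to compound 3 (0.15 log units; within the scatter) and a 4.7-fold higher number from compound 2 to compound 3 (0.67 log units; beyond the scatter). Compound 4 `Cn1cc(-c2cnc3[nH]cc(-c4cccc([N+](=O)[O-])c4)c3c2)cn1` differs from compound 2 by nitro in place of fluoro on an aromatic carbon. Among the compounds with values here, no measured step here places a nitro group anywhere; the two steps that bear on the same aromatic carbon are a 6.7-fold lower number from compound 1 to compound 2 (0.82 log units; beyond the scatter), which removes that fluoro back to hydrogen, and a 4.7-fold higher number from compound 2 to compound 3 (0.67 log units; beyond the scatter), which moves it. Both were modest and beyond the scatter, so the position carries weight, but the direction for a nitro group is not shown by any pair. On this footing the expected step is no change at the digits printed from compound 2 to compound 4 (within the scatter), small and uncertain in direction. For compound 4 the estimated value in this assay is 3000 nM, expected to fall between 800 nM and 12000 nM.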

Compound 4, solubility: 2000 nM
Estimate against measurement, compound 4: 1.5-fold (0.18 log units) above, and the stated range covers the measured number.
By their numbers in this assay, from the lowest: compounds 4 and 2 (each within the scatter of the next); then compounds 3 and 1 (each within the scatter of the next).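

In this assay the exchange of nitro for fluoro at this position gives a 1.5-fold lower number from compound 2 to compound 4 (0.18 log units; within the scatter), so the two groups, which differ in size and in hydrogen-bond acceptors, cannot be told apart on this read-out. Against hydrogen on the same carbon, nitro gives a 10-fold lower number from compound 1 to compound 4 (1.00 log units; beyond the scatter), which shows that the drop seen with fluoro at this position is not confined to fluoro but appears with a second group as well. No measurement in hand gives a reason for this likeness between the two groups.

The compounds shown leave open whether an amine or a carboxylic acid on this carbon would stay with compounds 2 and 4 or return towards compound 1. They also leave open how nitro would read on the carbon that carries fluoro in compound 3.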